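Swapping an Oxygen Link for a Sulfur Link

A few compounds are considered here, and "the series" means these few. Any claim that something is new, unique, unknown or untested is made for them only; others in the source may bear on it.

Measured compounds:
compound 1 `Nc1cc(N)c2nc(-c3ccccc3)c(Oc3ccc(Cl)c(Cl)c3)nc2c1`, < 100000 nM
compound 2 `CCOC(=O)[C@H](CCC(=O)O)NC(=O)c1ccc(Sc2nc3cc(N)cc(N)c3nc2-c2ccccc2)cc1`, < 100000 nM
compound 3 `COc1cc(CNc2nc3cc(N)cc(N)c3nc2-c2ccccc2)cc(OC)c1OC`, 34700 nM

All three values come from a functional assay on M14 cells (Homo sapiens) for inhibition, read by sulforhodamine B assay, with a stated time of 48 h; a lower number here means that less compound is tolerated, a higher number that more compound is tolerated. The value of compound 1 is a limit of the assay, not a number. The value of compound 2 is likewise a limit. Only compound 3 yields a number in this assay, 34700 nM. Compound 1 therefore has no definite place among the values shown; it sits at the limit of < 100000 nM in this assay, at which 2 of the 3 values shown sit, together with compound 2.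

Compound 4 `Nc1cc(N)c2nc(-c3ccccc3)c(Sc3ccc(Cl)c(Cl)c3)nc2c1` is the unmeasured compound. It differs from compound 1 in one place: (3,4-dichlorophenyl)sulfanyl in place of 3,4-dichlorophenoxy on an aromatic carbon. Among the compounds with values here, no pair of measured compounds shows this oxygen-to-sulfur exchange, so there is no measured step to lean on. The expectation is that the step from compound 1 to compound 4 is a step that the limit leaves unreadable from compound 1 to compound 4, with no change beyond the scatter, and that compound 4 may again come out at the limit. Compound 4 is estimated at 50000 nM, with a range from 10000 nM to 100000 nM.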

Compound 4, concentration lethal to 50% of the cells: < 100000 nM
Compound 4: a limit, no number (the forecaster's own chance of this, stated with the estimate: 55%); the middle value is on the limit's open side.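

Within the data shown here, compound 4 gives < 100000 nM as a limit and not a number, and with compound 1 also at a limit, no step between compound 1 and compound 4 can be read. The compounds shown leave open whether the sulfur link differs from the oxygen link in this read-out at all, since most values sit at one point: the limit of < 100000 nM in this assay, at which 3 of the 4 values shown sit.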